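Isopropyl for Piperidinylethyl: Expectation for Compound 4

The compounds below may be only part of what the source reports. "The series", "measured", "known", "first", "only" and "open" are said of these compounds alone.

Measured compounds:
Compound 1 `c1ccc2c(NC3CCCCCC3)nc(N3CCC(N4CCCC4)CC3)nc2c1`: 10%
Compound 2 `COc1cc2nc(N3CCC(N4CCCC4)CC3)nc(N3CCCCC3)c2cc1OC`: 8%
Compound 3 `COc1cc2nc(NCCN3CCCCC3)nc(NC3CCCCCC3)c2cc1OC`: 1%

In an in vitro functional assay on B300-19 cells for antagonist activity at C-C chemokine receptor type 4 (Homo sapiens), read by GTPgammaS binding, tested at 1 uM (on this read-out lower numbers stand for less inhibition and higher numbers for more inhibition at the one concentration tested (going by the name of the read-out)), compound 1 gives 10%, compound 2 gives 8% and compound 3 gives 1%. Compound 3 holds the lowest of the three numbers, yet its gaps to compound 2 and to compound 1 both lie within the scatter, so no order among the three can be read. Compound 4 `COc1cc2nc(NC(C)C)nc(NC3CCCCCC3)c2cc1OC` differs from compound 3 in one place: isopropyl in place of 2-(piperidin-1-yl)ethyl on a nitrogen on an aromatic ring. Among the compounds with values here, no step between measured compounds is available to guide this change. Because compound 3 stands at 1% and the other two measured compounds sit nearby, compound 4 is expected to stay low, with a step of a number 3 percentage points higher from compound 3 to compound 4 (within the scatter) that does not go beyond the scatter. The estimate for compound 4 is 4%, ranging from -8% to 18%.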

Compound 4, a percentage reported as inhibition, at one concentration (the size of the read-out at that concentration, not a potency): < 0%
Compound 4: no number, only a limit; the forecaster's own chance of this, stated with the estimate: 0%; at least 4 percentage points between middle value and limit.
By their numbers in this assay, from the lowest: compounds 3, 2 and 1 (each within the scatter of the next). At a limit, below all of these: compound 4.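

In this assay compound 4 gives < 0%, which is a limit of the assay and not a number. Within the data shown here, the change from 2-(piperidin-1-yl)ethyl to isopropyl on this nitrogen is the first single-place step available here, and it reads as a number at least 1 percentage points lower from compound 3 to compound 4 (that floor lies within the scatter). On this nitrogen, then, the open chain with its six-membered ring and the small isopropyl both leave inhibition low, with no separation beyond the scatter. From the compounds shown here alone, whether any other group here would lift inhibition remains open, for instance a primary amine or a longer chain ending in a carboxylic acid.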